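This account rests on a few compounds, and the source may have more. Where it says the series, first, only, none or still open, it means among the compounds named here.

Measured compounds in an assay on cells for displacement of a labelled ligand from prostaglandin E2 receptor EP4 subtype (Homo sapiens), read by scintillation counting; a higher number here means a weaker inhibitor, a lower number a stronger inhibitor:
compound 1, `Cc1oc(C(=O)O)cc1COc1ccc(-c2ccc(CO)cc2)cc1`, gives 3000 nM
compound 2, `Cc1oc(C(=O)O)cc1COc1ccc(-c2ccc(C#N)cc2)cc1`, gives 1500 nM

Compound 2 and compound 1 lie within the scatter of each other, as a 2.0-fold lower number from compound 1 to compound 2 (0.30 log units; within the scatter) shows; no ranking between them is warranted. Compound 3, `CNC(=O)c1ccc(-c2ccc(OCc3cc(C(=O)O)oc3C)cc2)cc1`, differs from compound 2 by methylcarbamoyl in place of cyano on an aromatic carbon. Among the measured compounds shown here, the only measured step, a 2.0-fold lower number from compound 1 to compound 2 (0.30 log units; within the scatter), exchanged a different group at this same position and stayed within the scatter; no measured step involves methylcarbamoyl. A step beyond the scatter is therefore not expected, and compound 3 is estimated at 1500 nM (range 500 nM to 5000 nM), meaning an expected step of no change at the digits printed from compound 2 to compound 3 (within the scatter).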

Compound 3, inhibition constant: > 10000 nM
Compound 3: no number, only a limit; the forecaster's own chance of this, stated with the estimate: 5%; middle value at least 6.6-fold (0.82 log units) away from the limit.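

This position on an aromatic carbon, para to a large group, is not indifferent to what it carries: the earlier exchange stayed within the scatter, but methylcarbamoyl gives an at least 6.6-fold higher number from compound 2 to compound 3 (0.82 log units; beyond the scatter) and an at least 3.3-fold higher number from compound 1 to compound 3 (0.52 log units; beyond the scatter). Going by these compounds, both steps rest on a limit and not on a number, so their true size is unknown. Compound 3 has no exact value in this assay, only a limit: the limit of > 10000 nM in this assay, at which 1 of the 3 values shown sits.

Which part of methylcarbamoyl goes with this loss remains open. A plain carboxamide, a dimethylcarboxamide or a carboxylic acid at this position would help separate the amide hydrogen from the added methyl.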